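Adding an amino group to compound 1

The compounds below may be only part of what the source reports. "The series", "measured", "known", "first", "only" and "open" are said of these compounds alone.

Compound 1 `CCn1cc(-c2nc3ccccc3[nH]2)c(=O)c2cc(F)c(N3CCNCC3)nc21` - > 10000 nM
Compound 2 `CCn1cc(-c2nc3ccc([N+](=O)[O-])cc3s2)c(=O)c2cc(F)c(N3CCNC(C)C3)c(F)c21` - 1000 nM

In a functional assay on HT-29 cells (Homo sapiens) for cytotoxicity, read by sulforhodamine B assay, with a stated time of 48 h (on this read-out lower numbers stand for stronger inhibition of growth and higher numbers for weaker inhibition of growth), compound 1 gives > 10000 nM, which is a limit of the assay and not a number. On these data alone, its true position therefore remains open. Compound 3 `CCn1cc(-c2nc3ccc(N)cc3[nH]2)c(=O)c2cc(F)c(N3CCNCC3)nc21` departs from compound 1 by a single change (amino in place of hydrogen on an aromatic carbon), amino in place of hydrogen on an aromatic carbon. Among the compounds with values here, no measured pair shows what this change does in this assay, so only a modest gain in growth inhibition is expected. The expected size of this move is an at least 1.1-fold lower number from compound 1 to compound 3 (0.04 log units; that floor lies within the scatter). Compound 3 is estimated at 9000 nM, with an expected range from 2500 nM to 30000 nM.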

Compound 3, concentration for 50% growth inhibition: > 10000 nM
Compound 3 ended at the assay's limit; the forecaster's own chance of this, stated with the estimate: 50%; middle value at least 1.1-fold (0.04 log units) from the limit.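

No step can be read between compound 1 and compound 3, because both stand at the same limit: the limit of > 10000 nM in this assay, at which 2 of the 3 values shown sit.

On these data alone, what amino in place of hydrogen does to growth inhibition, and how far either compound lies past that limit, remains open.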